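Thiazole acetic acids: para-trifluoromethyl variant of compound 2

This account rests on a few compounds, and the source may have more. Where it says the series, first, only, none or still open, it means among the compounds named here.

Measured so far:
compound 1 `O=C(O)Cc1sc(COc2ccc(Cl)cc2)nc1-c1ccc(Cl)cc1` 370 nM
compound 2 `O=C(O)Cc1sc(C(c2ccccc2)c2ccccc2)nc1-c1ccccc1` 370 nM

In an in vitro functional assay on HEK285-7 cells for antagonist activity at prostaglandin D2 receptor 2 (Homo sapiens), read by BRET and beta-arrestin recruitment (a lower number here means a stronger inhibitor, a higher number a weaker inhibitor), compound 1 gives 370 nM and compound 2 gives 370 nM, so compound 2 stands level with compound 1 within the scatter. Compound 3 `O=C(O)Cc1sc(C(c2ccccc2)c2ccccc2)nc1-c1ccc(C(F)(F)F)cc1` differs from compound 2 by trifluoromethyl in place of hydrogen on an aromatic carbon. Among the compounds with values here, no measured pair shows this exact change, so only a small step is expected, if any, and a slight gain seems as plausible as none. The step from compound 2 to compound 3 is estimated at a 1.5-fold lower number from compound 2 to compound 3 (0.17 log units; within the scatter) in this assay. Compound 3 is expected to give about 250 nM, within 80 nM to 900 nM.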

Compound 3, half-maximal inhibitory concentration: > 100000 nM
Compound 3 gave a limit, no number (the forecaster's own chance of this, stated with the estimate: 3%); middle value at least 400-fold (2.60 log units) away from the limit.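

For compound 3 the read-out is a limit of this assay, not a number: the limit of > 100000 nM in this assay, at which 1 of the 3 values shown sits. Phenyl to 4-(trifluoromethyl)phenyl gives an at least 270-fold higher number from compound 2 to compound 3 (2.43 log units; beyond the scatter), the only one-place comparison in the series. Within the data shown here, compound 1 and compound 2 offered no such pair, and this one shows that this aromatic carbon, para to a large group, does not freely accept substitution.

As far as these compounds go, whether a smaller group such as fluorine or methyl is accepted at this carbon stays open. So does whether the same change costs as much on the core of compound 1.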